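Phenyl in place of propyl on the chain carbon

The source may report more compounds than this note shows. Statements on the series, on what has been measured and on what is new or still open speak of the compounds shown alone.

In a functional assay on BT-474 cells (Homo sapiens) for inhibition, read by fluorescence, with a stated time of 72 h (on this read-out lower numbers stand for stronger inhibition of growth and higher numbers for weaker inhibition of growth), compound 3 `CCCCn1cnc2c(Nc3cccc(Cl)c3)nc(N[C@H]3CC[C@H](N)CC3)nc21` gives 5100 nM, level with compound 2 `CCCCCCn1cnc2c(Nc3cccc(Cl)c3)nc(N[C@H]3CC[C@H](N)CC3)nc21` at 5100 nM, while compound 1 `COc1ccc(Cn2cnc3c(Nc4cccc(Cl)c4)nc(N[C@H]4CC[C@H](N)CC4)nc32)cc1` gives 8200 nM. All three lie within the scatter of one another. Compound 4 `N[C@H]1CC[C@H](Nc2nc(Nc3cccc(Cl)c3)c3ncn(Cc4ccccc4)c3n2)CC1` differs from compound 3 by phenyl in place of propyl on a saturated chain carbon bound to an aromatic nitrogen. The closest measured change is a 1.6-fold lower number from compound 1 to compound 3 (0.21 log units; within the scatter), with propyl in place of 4-methoxyphenyl at that carbon. The other two, a 1.6-fold lower number from compound 1 to compound 2 (0.21 log units; within the scatter) and no change at the digits printed from compound 2 to compound 3 (within the scatter), also stay within the scatter. No step beyond the scatter is therefore expected in this assay. The expected step is a 1.2-fold higher number from compound 3 to compound 4 (0.07 log units; within the scatter). The estimate for compound 4 is 6000 nM, with an expected range of 3000 nM to 12000 nM.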

Compound 4, concentration for 50% growth inhibition: 10200 nM
Estimate against measurement, compound 4: 1.7-fold (0.23 log units) below, within the range that was stated.
By their numbers in this assay, from the lowest: compounds 2, 3, 1 and 4 (each within the scatter of the next).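

In this assay, phenyl on a saturated chain carbon bound to an aromatic nitrogen stays within the scatter of the alkyl chains (a 2.0-fold higher number from compound 3 to compound 4 (0.30 log units; within the scatter); a 2.0-fold higher number from compound 2 to compound 4 (0.30 log units; within the scatter)). Hydrogen in place of methoxy on an aromatic carbon also stays within it (a 1.2-fold higher number from compound 1 to compound 4 (0.09 log units; within the scatter)), so neither change at this place gives a step beyond the scatter. Nothing available explains these steps.

Still open, going by these compounds, is whether an amine, a carboxylic acid or a pyridine ring in place of phenyl on that carbon would give a step beyond the scatter.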